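Taking the Fluoro Off the Aryl Ring of Compound 2

The source may report more compounds than this note shows. Statements on the series, on what has been measured and on what is new or still open speak of the compounds shown alone.

Of the compounds shown here, two sharing one core have been measured so far. Compound 1 `Cc1ccccc1C1C(C#N)=C(N)OC(c2c[nH]c3ccccc23)=C1C#N` and compound 2 `N#CC1=C(N)OC(c2c[nH]c3ccccc23)=C(C#N)C1c1ccc(F)cc1` differ only on a saturated ring carbon, where compound 1 carries 2-methylphenyl and compound 2 carries 4-fluorophenyl. In a functional assay, tested at 100 ug/mL (on this read-out lower numbers stand for a weaker effect and higher numbers for a stronger effect at the one concentration tested), compound 1 gives 17.2%, and compound 2 gives 16.2%. The only measured step, a number 1 percentage points lower from compound 1 to compound 2 (within the scatter), stays within the scatter, so on the numbers shown compound 2 stands level with compound 1 rather than apart from it.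

Compound 3 `N#CC1=C(N)OC(c2c[nH]c3ccccc23)=C(C#N)C1c1ccccc1` has not yet been measured. Its difference from compound 2 is hydrogen in place of fluoro on an aromatic carbon, which cut one bond further out reads 4-fluorophenyl to phenyl. Among the measured compounds shown here, no measured step touches this change directly; the one step available, a number 1 percentage points lower from compound 1 to compound 2 (within the scatter), swapped the whole aryl group and still moved the read-out within the scatter. Hydrogen in place of fluoro is a smaller change than that, so no step beyond the scatter is expected in this assay. Compound 3 is therefore expected to give about 16%, between 7% and 26%. For compound 3 this amounts to an expected a number 0.2 percentage points lower from compound 2 to compound 3 (within the scatter), within the scatter.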

Compound 3, a percentage reported as activity, at one concentration (the size of the read-out at that concentration, not a potency): 19.3%
The estimate for compound 3 lay 3.3 percentage points below the measured number; the range from low to high includes it.
By their numbers in this assay, from the lowest: compounds 2, 1 and 3 (each within the scatter of the next).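

In this assay, hydrogen in place of fluoro on an aromatic carbon, para to a large group, gives a number 3.1 percentage points higher from compound 2 to compound 3 (within the scatter), and dropping the methyl from the aryl group gives a number 2.1 percentage points higher from compound 1 to compound 3 (within the scatter) as the second step at the aryl ring. Among the compounds shown here, the earlier compounds showed only that one substituted aryl group could stand in for another; compound 3 adds the plain phenyl, and it shows that neither fluoro nor methyl is needed to keep the read-out in the same range, with all three compounds level within the scatter. Nothing measured on these groups accounts for this result.

Going by these compounds, whether an amine or a carboxylic acid on the aryl ring, or a longer chain in place of that ring, would carry the read-out beyond the scatter remains open. This read-out also comes from a single concentration, so the three compounds leave open whether their potencies differ, even though their effects at that concentration stand level.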